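Aryl variation on the imine carbon of the shared core

This account rests on a few compounds, and the source may have more. Where it says the series, first, only, none or still open, it means among the compounds named here.

Measured so far in a functional assay, with a stated time of 30 min; a lower number here means a stronger inhibitor, a higher number a weaker inhibitor:
compound 1 `CCCCc1oc2ccc(/N=C/c3cccc([N+](=O)[O-])c3)cc2c1C(=O)c1ccc(OC)cc1`: 34.2 ug/mL
compound 2 `CCCCc1oc2ccc(/N=C/c3ccc(F)cc3)cc2c1C(=O)c1ccc(OC)cc1`: 100 ug/mL
compound 3 `CCCCc1oc2ccc(/N=C/c3ccc([N+](=O)[O-])cc3)cc2c1C(=O)c1ccc(OC)cc1`: 53.1 ug/mL

Compound 3 holds the second highest of the three numbers in this assay. The step of a 1.6-fold higher number from compound 1 to compound 3 (0.19 log units; within the scatter) and the step of a 1.9-fold lower number from compound 2 to compound 3 (0.27 log units; within the scatter) both lie within the scatter, so compound 3 cannot be ordered against either neighbour; only a 2.9-fold higher number from compound 1 to compound 2 (0.47 log units; beyond the scatter) is beyond the scatter, and that step is modest.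

Compound 4 `CCCCc1oc2ccc(/N=C/c3ccccc3O)cc2c1C(=O)c1ccc(OC)cc1` differs from compound 3 in one place: 2-hydroxyphenyl in place of 4-nitrophenyl on a carbon with a double bond to nitrogen. Among the compounds with values here, no measured step brings a hydroxyl onto the aryl at this carbon. The aryl changes that are measured, a 1.9-fold lower number from compound 2 to compound 3 (0.27 log units; within the scatter) and a 1.6-fold higher number from compound 1 to compound 3 (0.19 log units; within the scatter), stayed within the scatter, while a 2.9-fold higher number from compound 1 to compound 2 (0.47 log units; beyond the scatter) shows that a modest shift is possible. Within the data shown here, a step of at most modest size is therefore expected, leaning toward a higher number since the one compound without a nitro group, compound 2, gives 100 ug/mL.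

Compound 4 is expected to give 60 ug/mL, with a range of 30 ug/mL to 130 ug/mL. The expected step of a 1.1-fold higher number from compound 3 to compound 4 (0.05 log units; within the scatter) is estimated to stay close to the scatter.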

Compound 4, half-maximal inhibitory concentration: 99.4 ug/mL
Compound 4: the middle estimate sits 1.7-fold (0.22 log units) below what was measured; low and high end bracket the measured number.
By their numbers in this assay, from the lowest: compounds 1, 3, 4 and 2 (each within the scatter of the next, the first and the last beyond it).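

In this assay, 2-hydroxyphenyl on the imine carbon cannot be told apart from either 4-nitrophenyl (a 1.9-fold higher number from compound 3 to compound 4 (0.27 log units; within the scatter)) or 4-fluorophenyl (a 1.0-fold lower number from compound 2 to compound 4 (0.00 log units; within the scatter)), so bringing a hydrogen-bond donor onto this aryl gives no separation from the aryl groups that have none. Within the data shown here, only the step from the 3-nitrophenyl compound stands out (a 2.9-fold higher number from compound 1 to compound 4 (0.46 log units; beyond the scatter)), and it is modest. Compound 1 is thus separated from compound 2 and compound 4 but not from compound 3, so the four aryl groups do not fall into distinct groups and the position has so far shown only modest steps.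

As far as these compounds go, whether a 2-methoxyphenyl, a 2-aminophenyl or a 4-carboxyphenyl at this carbon would stand apart from compound 4 remains open. Nothing at hand accounts for the numbers at this position.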